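The source may hold more compounds than are shown below. What is called first, only, known or untested is meant among the compounds shown, and "the series" means these compounds.

Compound 1 `COc1ccc2[nH]c(-c3ccccc3)c(C=C(C#N)C#N)c2c1`: 3100 nM
Compound 2 `COc1ccc(-c2[nH]c3ccc(OC)cc3c2C=C(C#N)C#N)cc1`: 424 nM
Compound 3 `COc1ccc2[nH]c(-c3ccccc3)c(/C=C(\C#N)S(=O)(=O)c3ccccc3)c2c1`: 5000 nM

All three were tested in a functional assay on OVCAR-3 cells (Homo sapiens) for inhibition, read by sulforhodamine B assay, with a stated time of 48 h; on this read-out lower numbers stand for stronger inhibition of growth and higher numbers for weaker inhibition of growth. Compound 1 differs from compound 2 in one place: hydrogen in place of methoxy on an aromatic carbon. That change gave a 7.3-fold higher number from compound 2 to compound 1 (0.86 log units; beyond the scatter). Compound 3 carries a different core; the difference between the two cores is not broken down here. In this assay compound 3 gives 5000 nM, close to compound 1 and far from compound 2.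

Compound 4 `N#C/C(=C\c1c(-c2ccccc2)[nH]c2ccccc12)S(=O)(=O)c1ccccc1` has not yet been measured. It differs from compound 3 by hydrogen in place of methoxy on an aromatic carbon. Among the measured compounds shown here, this is the same kind of change as the one from compound 2 to compound 1, but not the same: there the methoxy sat on a six-membered aromatic ring of carbon only, para to a large group, whereas here it leaves a ring that is part of a fused or bridged system of two rings, meta to a fused ring and para to a fused ring. The earlier step is thus only a rough guide. In this assay compound 4 is expected to give 10000 nM, with a likely range from 4000 nM to 30000 nM. That amounts to an expected step of a 2.0-fold higher number from compound 3 to compound 4 (0.30 log units; within the scatter), smaller than a 7.3-fold higher number from compound 2 to compound 1 (0.86 log units; beyond the scatter).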

Compound 4, concentration for 50% growth inhibition: 1400 nM
Estimate against measurement, compound 4: 7.1-fold (0.85 log units) above, outside the stated range (below it).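

In this assay, putting hydrogen in place of the methoxy on the fused system of two rings gave a 3.6-fold lower number from compound 3 to compound 4 (0.55 log units; beyond the scatter), so growth inhibition became stronger on this core. The same kind of change moved the number the opposite way on the other core, and the gap between the two steps is real rather than scatter: the same change on two cores in this assay, a 7.3-fold higher number (0.86 log units; beyond the scatter) from compound 2 to compound 1 and a 3.6-fold lower number (0.55 log units; beyond the scatter) from compound 3 to compound 4, 26-fold (1.42 log units) apart, beyond the scatter of two such steps. This shows that the effect of losing a methoxy cannot simply be carried from one core to another in this series, but it does not show what sets the direction, since the two pairs differ both in the ring that loses the methoxy and in the rest of the core.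

A pair losing a methoxy from the same ring on both cores would separate those two differences. As far as these compounds go, it also remains open how other groups would behave at the place of the methoxy on compound 4, such as a hydroxyl, an amine or a carboxylic acid.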